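The source may report more compounds than this note shows. Statements on the series, on what has been measured and on what is new or still open speak of the compounds shown alone.

Compound 1 `Cn1cc(C2=C(c3n[nH]c4ncccc34)C(=O)NC2=O)c2ccccc21` and compound 2 `CN1CCN(CCCn2nc(C3=C(c4cn(C)c5ccccc45)C(=O)NC3=O)c3cccnc32)CC1` share one core, and in a functional assay on ECa-109 cells (Homo sapiens) for antiproliferative activity, read by MTT assay, with a stated time of 48 h (a higher number here means a weaker inhibitor, a lower number a stronger inhibitor), compound 1 gives 46100 nM. In this assay compound 2 gives only the limit > 100000 nM, and no number. Going by the values given here, the one step measured along this series, an at least 2.1-fold higher number from compound 1 to compound 2 (0.33 log units; beyond the scatter), is the only change whose effect is known here. Among the compounds with values here, compound 3 `CN(C)CCCn1nc(C2=C(c3cn(C)c4ccccc34)C(=O)N(c3ccccc3)C2=O)c2cccnc21` differs from compound 2 in two places, and in this assay compound 3 gives 5840 nM; no single step joins it to compound 2, so its value shows only that a member of the series can reach that level.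

Compound 4 `Cn1cc(C2=C(c3nn(CCCN4CCCCC4)c4ncccc34)C(=O)NC2=O)c2ccccc21` is not yet measured. It differs from compound 2 in one place: piperidin-1-yl in place of 4-methylpiperazin-1-yl on a saturated chain carbon, three bonds along the chain from an aromatic nitrogen. Within the data shown here, no measured step exchanges one such ring for another, so nothing among the measured values speaks to the size or the direction of this change, and compound 2 itself stands only at the limit (the limit of > 100000 nM in this assay, at which 1 of the 3 values shown sits). The author therefore expects compound 4 to remain a weak inhibitor, with a step of an at least 1.2-fold lower number from compound 2 to compound 4 (0.09 log units; that floor lies within the scatter) that may be no larger than the scatter. For compound 4 the estimate in this assay is 80000 nM, with a range from 25000 nM to 300000 nM.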

Compound 4, half-maximal inhibitory concentration: 42300 nM
Compound 4: middle estimate off by 1.9-fold (0.28 log units), on the high side, and the stated range covers the measured number.
By their numbers in this assay, from the lowest: compound 3; then compounds 4 and 1 (each within the scatter of the next). At a limit, above all of these: compound 2.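

Compound 2 stands at a limit and not at a number: the limit of > 100000 nM in this assay, at which 1 of the 4 values shown sits.

Even so, piperidin-1-yl in place of 4-methylpiperazin-1-yl on a saturated chain carbon, three bonds along the chain from an aromatic nitrogen, gives an at least 2.3-fold lower number from compound 2 to compound 4 (0.37 log units; beyond the scatter) in this assay, so an exchange of one such ring for another now has a measured direction and a floor on its size. The 3-(piperidin-1-yl)propyl group in place of hydrogen on an aromatic nitrogen gives a 1.1-fold lower number from compound 1 to compound 4 (0.04 log units; within the scatter), so compound 1 and compound 4 cannot be told apart here, whereas the 3-(4-methylpiperazin-1-yl)propyl group at that nitrogen gave an at least 2.1-fold higher number from compound 1 to compound 2 (0.33 log units; beyond the scatter).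

The full size of the exchange between the two rings stays unread, since only its floor is known. The compounds shown also leave open whether a morpholine or a pyrrolidine ring on the same chain, or a longer chain carrying the piperidine ring, would keep the number at the level of compound 4 or move it.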